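The source may report more compounds than this note shows. Statements on the series, on what has been measured and on what is new or still open speak of the compounds shown alone.

Measured in a functional assay on CEM-DNR-bulk cells (Homo sapiens), read by MTT assay, with a stated time of 72 h; on this read-out higher numbers stand for weaker inhibition and lower numbers for stronger inhibition:
- compound 1 `CNc1ncnc2c1c(-c1ccoc1)cn2[C@@H]1O[C@H](CO)[C@@H](O)[C@H]1O`: > 20000 nM
- compound 2 `Nc1nc(N)c2c(-c3ccco3)cn([C@@H]3O[C@H](CO)[C@@H](O)[C@H]3O)c2n1`: > 20000 nM
- compound 3 `Nc1nc(N)c2c(-c3cccs3)cn([C@@H]3O[C@H](CO)[C@@H](O)[C@H]3O)c2n1`: > 20000 nM

All three entries are limits, not numbers. Among the measured compounds shown here, the series so far amounts to the limit of > 20000 nM in this assay, at which 3 of the 3 values shown sit.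

Compound 3 gives > 20000 nM, which is a limit, so its position can be stated only as that limit and no number is available to anchor a step.

The next compound is compound 4 `Nc1nc(N)c2c(-c3ccsc3)cn([C@@H]3O[C@H](CO)[C@@H](O)[C@H]3O)c2n1`, with thiophen-3-yl in place of thiophen-2-yl on an aromatic carbon. The two have the same atoms, joined differently.

For the measured compounds named here, the only measured step bearing on this change is a step that the two limits leave unreadable from compound 2 to compound 3. That step also replaces one five-membered aromatic ring with another at the same place, but it gives no size to carry over. With no readable step in the series, no step beyond the scatter is expected in this assay, and no direction can be assigned. Compound 4 is most likely to be reported as a limit as well.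

The expected change is a number no higher from compound 3 to compound 4 (the limit leaves the size open).

For compound 4 the estimated value is 20000 nM, with an expected range from 9000 nM to 30000 nM.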

Compound 4, half-maximal inhibitory concentration: > 20000 nM
Compound 4: only a limit was reported; the forecaster's own chance of this, stated with the estimate: 80%; the middle value sits exactly at the limit.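

In this assay, among the compounds shown here, compound 4 gives > 20000 nM, which is a limit, so no step from compound 2 or compound 3 to compound 4 can be read. The compounds shown leave open whether furan-2-yl, thiophen-2-yl and thiophen-3-yl differ at all in this assay, since the series so far stands at: the limit of > 20000 nM in this assay, at which 4 of the 4 values shown sit.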